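Substituent swap on the shared core: compound 3 estimate

This account rests on a few compounds, and the source may have more. Where it says the series, first, only, none or still open, it means among the compounds named here.

Measured:
compound 1 `CCCNc1cccnc1-c1ccc(C(=O)Nc2ccc(C(C)(C)C)cc2)cc1` — 158 nM
compound 2 `CC(C)(C)c1ccc(NC(=O)c2ccc(-c3ncccc3N(S(C)(=O)=O)S(C)(=O)=O)cc2)cc1` — 0.8 nM

In a functional assay for antagonist activity at transient receptor potential cation channel subfamily V member 1 (Homo sapiens), read by FLIPR (on this read-out lower numbers stand for stronger inhibition and higher numbers for weaker inhibition), compound 2 gives the lowest of the two numbers; its nearest neighbour is compound 1, with compound 1 giving 158 nM. For the measured compounds named here, the one measured step, a 200-fold lower number from compound 1 to compound 2 (2.30 log units; beyond the scatter), is large and well beyond the scatter, and it turns on the group at the same position as the change now considered.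

Compound 3 `CC(C)(C)c1ccc(NC(=O)c2ccc(-c3ncccc3C(=N)N)cc2)cc1` is not yet measured in this assay. It differs from compound 2 by a group of 3 heavy atoms (1 carbon, 2 nitrogen; no ring) in place of a group of 9 heavy atoms (2 carbon, 1 nitrogen, 4 oxygen, 2 sulfur; no ring), on an aromatic carbon. The step of a 200-fold lower number from compound 1 to compound 2 (2.30 log units; beyond the scatter) shows how much the bis(methylsulfonyl)amino group contributes on this core; replacing it with a small group of three heavy atoms is expected to give back a good part of that gain, so a step upward in this assay is expected, a 130-fold higher number from compound 2 to compound 3 (2.10 log units; beyond the scatter). For compound 3 the expected value is 100 nM, with a range from 10 nM to 1500 nM.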

Compound 3, half-maximal inhibitory concentration: > 4000 nM
Compound 3 gave a limit, no number (the forecaster's own chance of this, stated with the estimate: 5%); middle value at least 40-fold (1.60 log units) away from the limit.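

Compound 3 gives a limit and not a number in this assay: the limit of > 4000 nM in this assay, at which 1 of the 3 values shown sits.

Leaving bis(methylsulfonyl)amino for the group of 3 heavy atoms does more than hand back the earlier gain: the change gives an at least 5000-fold higher number from compound 2 to compound 3 (3.69 log units; beyond the scatter), and the comparison with propylamino gives an at least 25-fold higher number from compound 1 to compound 3 (1.40 log units; beyond the scatter). For the compounds shown here, the earlier pair showed only that a group at this aromatic carbon can lower the number, whereas these three compounds show that a group here can also put the read-out on the far side of propylamino.

On these data alone, with compound 3 at a limit, the true size of both steps stays unknown. Open, as far as these compounds go, is where a primary amine, a nitrile or a nitrogen carrying a single methylsulfonyl group would fall at this position on the shared core.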